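The source may hold more compounds than are shown below. What is called first, only, known or untested is meant among the compounds shown, and "the series" means these compounds.

In a physicochemical assay for lipophilicity (on this read-out higher numbers stand for higher lipophilicity and lower numbers for lower lipophilicity), compound 3, `CCNC(=O)c1cc(C(=O)NC)nn1[C@@H](C)c1ccccc1`, gives 3.7, the highest of the three numbers recorded so far. Compound 1, `CNC(=O)c1cc(C(=O)N[C@H]2CC[C@H](O)CC2)c([C@@H](C)c2cccc(C)c2)o1`, gives 3.3 in this assay, the nearest of the other two and lower by more than the usual scatter. Compound 2, `CNC(=O)c1cc(C(=O)NC2CC2)n(Cc2ccccc2)n1`, gives 3.1 in this assay, the furthest of the three and likewise lower by more than the scatter. Among the compounds with values here, no pair of measured compounds differs in only one place, so no measured step bears directly on the change under consideration. Compound 4, `CNC(=O)c1cc(C(=O)NC)n([C@@H](C)c2ccccc2)n1`, has not yet been measured. It differs from compound 3 in a single place: hydrogen in place of methyl on a saturated chain carbon bound to an amide-type nitrogen. The hydrogen enters on a saturated chain carbon bound to an amide-type nitrogen, so that ethylcarbamoyl becomes methylcarbamoyl. Since one carbon leaves and no donor or acceptor count shifts, a small downward step is expected, a number 0.40 log units lower from compound 3 to compound 4 (beyond the scatter), of about the size of the scatter. Compound 4 is accordingly estimated at 3.3, with a range from 2.9 to 3.7.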

Compound 4, distribution coefficient: 3
The estimate for compound 4 lay 0.30 log units above the measured number; the range from low to high includes it.
By their numbers in this assay, from the lowest: compounds 4, 2 and 1 (each within the scatter of the next); then compound 3.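

In this assay, shortening ethylcarbamoyl to methylcarbamoyl gives a number 0.70 log units lower from compound 3 to compound 4 (beyond the scatter), the only single-place step in the series shown. Compounds 1 and 2 differ from the others in several places at once, so they could not show that this position alone can move the read-out by more than the usual scatter. Nothing in the data accounts for the size of this step.

The two points, ethyl and methyl, do not show whether a longer chain such as propyl, or an amine on the same chain, would continue the same direction. As far as these compounds go, it also remains open whether the same change from ethylcarbamoyl to methylcarbamoyl would give a step of similar size on the core of compound 1 or compound 2.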